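A few compounds are considered here, and "the series" means these few. Any claim that something is new, unique, unknown or untested is made for them only; others in the source may bear on it.

The series shares the core seen in compound 1 `Cc1ccc(C(=O)N/N=C/C2=C(Cl)c3ccccc3CCC2)cc1`, which in a functional assay (MiaPaCa cells, Homo sapiens) for inhibition, read by sulforhodamine B assay, with a stated time of 48 h (on this read-out lower numbers stand for stronger inhibition of growth and higher numbers for weaker inhibition of growth), gives 10000 nM. Compound 2 `Cc1cc2c(cc1C)C(Cl)=C(/C=N/NC(=O)c1ccccc1)CCC2` carries methyl groups on the fused aromatic ring and an unsubstituted phenyl on the amide side. In this assay compound 2 reaches only the assay limit, > 100000 nM, so no number is known for it. Its position is that of the limit of > 100000 nM in this assay, at which 1 of the 2 values shown sits. Compound 3 `Cc1cc2c(cc1C)C(Cl)=C(/C=N/NC(=O)c1ccccc1N)CCC2` differs from compound 2 by amino in place of hydrogen on an aromatic carbon. Within the data shown here, no step between measured compounds covers this change, so its size cannot be read from the data. The starting point is a limit, not a number. The expected step is an at least 1.6-fold lower number from compound 2 to compound 3 (0.22 log units; that floor lies within the scatter), most likely toward a measurable but still weak value, with a real chance that only a limit is reported again. Compound 3 is expected at 60000 nM, within 15000 nM to 200000 nM.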

Compound 3, concentration for 50% growth inhibition: 810 nM
Compound 3: the middle estimate sits 74-fold (1.87 log units) above what was measured, outside the stated range (below it).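

The change from phenyl to 2-aminophenyl gives an at least 120-fold lower number from compound 2 to compound 3 (2.09 log units; beyond the scatter) in this assay and is the only difference between the two compounds. Among these compounds, a single amino group on an aromatic carbon, ortho to a large group, is therefore enough to turn a compound without a measurable value into one with a measured value, which the earlier compounds could not show. The printed step is only a floor and the full size of the change remains unknown, because the entry for compound 2 is a limit of the assay and not a number: the limit of > 100000 nM in this assay, at which 1 of the 3 values shown sits.

As far as these compounds go, it remains open whether another group in the same place, such as a hydroxyl or a methylamino group, would give a comparable step. From the compounds shown here alone, it is also open whether the amino group would have a similar effect in compounds with other substitution on the fused aromatic ring.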